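Amine Swap at the Chain End: Compound 4 Expected

The source may hold more compounds than are shown below. What is called first, only, known or untested is meant among the compounds shown, and "the series" means these compounds.

Measured in a functional assay on SK-BR-3 cells (Homo sapiens) for antiproliferative activity; a lower number here means a stronger inhibitor, a higher number a weaker inhibitor:
compound 1, `CC(C)=CCc1cc(C(=O)Nc2cc3ccc(OCCC4CCCCN4)c(C)c3oc2=O)ccc1O`: 640 nM
compound 2, `CC(C)=CCc1cc(C(=O)Nc2cc3ccc(OCCCN4CCCC4)c(C)c3oc2=O)ccc1O`: 720 nM
compound 3, `CC(C)=CCc1cc(C(=O)Nc2cc3ccc(OCCCNC(C)(C)C)c(C)c3oc2=O)ccc1O`: 660 nM

Compound 2 holds the highest of the three numbers, but the steps of a 1.1-fold higher number from compound 1 to compound 2 (0.05 log units; within the scatter) and a 1.1-fold lower number from compound 2 to compound 3 (0.04 log units; within the scatter) both lie within the scatter, so no order among the three can be read. Compound 4 `CC(C)=CCc1cc(C(=O)Nc2cc3ccc(OCCCNCCO)c(C)c3oc2=O)ccc1O` differs from compound 2 by (2-hydroxyethyl)amino in place of pyrrolidin-1-yl on a saturated chain carbon, three bonds along the chain from an oxygen on an aromatic ring. Going by the values given here, the steps that bear on this place, a 1.1-fold higher number from compound 1 to compound 2 (0.05 log units; within the scatter) and a 1.1-fold lower number from compound 2 to compound 3 (0.04 log units; within the scatter), exchange one amine for another there and stay within the scatter; no amine bearing a hydroxyl is among the measured compounds. Compound 4 is therefore expected to give 700 nM (range 350 nM to 1400 nM). The expected step of a 1.0-fold lower number from compound 2 to compound 4 (0.01 log units; within the scatter) is estimated to stay within the scatter.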

Compound 4, half-maximal inhibitory concentration: 610 nM
For compound 4 the middle estimate is 1.1-fold (0.06 log units) above the measured one; low and high end bracket the measured number.
By their numbers in this assay, from the lowest: compounds 4, 1, 3 and 2 (each within the scatter of the next).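

In this assay, an amine carrying a hydroxyl at this place on the chain behaves like the amines before it: (2-hydroxyethyl)amino in place of pyrrolidin-1-yl stays within the scatter (a 1.2-fold lower number from compound 2 to compound 4 (0.07 log units; within the scatter)). So does 2-hydroxyethyl in place of tert-butyl on the amine nitrogen (a 1.1-fold lower number from compound 3 to compound 4 (0.03 log units; within the scatter)), and ((2-hydroxyethyl)amino)methyl in place of piperidin-2-yl (a 1.0-fold lower number from compound 1 to compound 4 (0.02 log units; within the scatter)). No evidence is available that bears on this result. The compounds shown leave open whether a carboxylic acid or an amide in place of the amine, or a longer chain leading to it, would move the number beyond the scatter.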